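This account rests on a few compounds, and the source may have more. Where it says the series, first, only, none or still open, it means among the compounds named here.

Measured so far in a functional assay on HT-29 cells (Homo sapiens) for antiproliferative activity, read by sulforhodamine B assay, with a stated time of 48 h; on this read-out higher numbers stand for weaker inhibition and lower numbers for stronger inhibition:
- compound 1 `CCCCCc1ccc(NS(=O)(=O)c2ccc(N3CCNC3=O)cc2)cc1`: 990 nM
- compound 2 `O=C1NCCN1c1ccc(S(=O)(=O)Nc2ccc(I)cc2)cc1`: 650 nM
- compound 3 `Cc1ccc(NS(=O)(=O)c2ccc(N3CCNC3=O)cc2)c(C)c1`: 180 nM

Compound 3 gives the lowest of the three numbers in this assay, its closest neighbour being compound 2 (a 3.6-fold lower number from compound 2 to compound 3 (0.56 log units; beyond the scatter)). Compound 4 `O=C1NCCN1c1ccc(S(=O)(=O)Nc2ccccc2)cc1` is the next change, made on the same sulfonamide nitrogen: phenyl in place of 2,4-dimethylphenyl on a sulfonamide nitrogen. Going by the values given here, two measured steps bear on it. The step of a 3.6-fold lower number from compound 2 to compound 3 (0.56 log units; beyond the scatter) shows that changing the aryl group on this nitrogen moves the number modestly; the step of a 1.5-fold lower number from compound 1 to compound 2 (0.18 log units; within the scatter) shows that swapping one substituent on that ring stayed within the scatter. Since only compound 3 carries the two methyl groups, taking them away is expected to raise the number somewhat, towards the value of compound 2. Compound 4 is therefore expected to give 500 nM (range 200 nM to 1500 nM), an expected step of a 2.8-fold higher number from compound 3 to compound 4 (0.44 log units; beyond the scatter).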

Compound 4, half-maximal inhibitory concentration: 280 nM
Beside the measured number, compound 4's estimate is 1.8-fold (0.25 log units) above it; low and high end bracket the measured number.
By their numbers in this assay, from the lowest: compounds 3 and 4 (each within the scatter of the next); then compounds 2 and 1 (each within the scatter of the next).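

Taking both methyl groups off the ring on the sulfonamide nitrogen gives a 1.6-fold higher number from compound 3 to compound 4 (0.19 log units; within the scatter) in this assay, so this ring needs neither methyl group to keep the number low. Compound 4 also shows what the ring's other substituents do: hydrogen in place of iodo gives a 2.3-fold lower number from compound 2 to compound 4 (0.37 log units; beyond the scatter) and hydrogen in place of pentyl gives a 3.5-fold lower number from compound 1 to compound 4 (0.55 log units; beyond the scatter), so here iodo and pentyl go with higher numbers than the bare phenyl.

From the compounds shown here alone, whether a single methyl, a methoxy or an amine on this ring would shift the number remains open. Nothing shown here explains these differences.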